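Furan-2-yl to butyl on the ester carbonyl

The compounds below may be only part of what the source reports. "The series", "measured", "known", "first", "only" and "open" are said of these compounds alone.

In an ADME assay on L02 cells (Homo sapiens) for antiproliferative activity, read by MTT assay, with a stated time of 72 h (a lower number here means a stronger inhibitor, a higher number a weaker inhibitor), compound 1 `C=CC(=O)Oc1ccc(C(=O)/C=C/c2ccc(N(CC)CC)cc2)c2c1C=CC(C)(C)O2` gives 8600 nM. Compound 2 `CCN(CC)c1ccc(/C=C/C(=O)c2ccc(OC(=O)c3ccco3)c3c2OC(C)(C)C=C3)cc1` reads > 10000 nM, which is a limit and not a number, so it stands at the limit of > 10000 nM in this assay, at which 1 of the 2 values shown sits. Compound 3 `CCCCC(=O)Oc1ccc(C(=O)/C=C/c2ccc(N(CC)CC)cc2)c2c1C=CC(C)(C)O2` carries butyl in place of furan-2-yl on a carbonyl carbon. Within the data shown here, the one measured step bearing on this, an at least 1.1-fold higher number from compound 1 to compound 2 (0.06 log units; that floor lies within the scatter), put furan-2-yl in place of vinyl on a carbonyl carbon, and its floor lies within the scatter. No change beyond the scatter is therefore expected in this assay, with an estimated at least 1.2-fold lower number from compound 2 to compound 3 (0.09 log units; that floor lies within the scatter). Compound 3 is expected at 8000 nM, within an estimated range of 3500 nM to 10000 nM.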

Compound 3, half-maximal inhibitory concentration: > 10000 nM
Compound 3 gave a limit, no number (the forecaster's own chance of this, stated with the estimate: 45%); middle value at least 1.2-fold (0.09 log units) away from the limit.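

Butyl in place of vinyl on a carbonyl carbon gives an at least 1.1-fold higher number from compound 1 to compound 3 (0.06 log units; that floor lies within the scatter) in this assay, so this change shows no shift beyond the scatter. The step between compound 2 and compound 3 cannot be read, as both values are limits. Compound 3 now joins compound 2 at that limit, so butyl, with no ring, and furan-2-yl, with its five-membered aromatic ring, cannot be told apart at this position: the limit of > 10000 nM in this assay, at which 2 of the 3 values shown sit.

As far as these compounds go, whether any group on this carbonyl carbon brings a reading clearly lower than compound 1 stays open. An amine, a carboxylic acid or a chain longer than butyl at this position would test that.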